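Swapping the hydroxy of compound 2 for nitro

A few compounds are considered here, and "the series" means these few. Any claim that something is new, unique, unknown or untested is made for them only; others in the source may bear on it.

Compound 1 `COc1ccc(CN(C(=O)CSc2nc3ccccc3s2)c2cc(OC)c(OC)c(OC)c2)cc1C`: 6360 nM
Compound 2 `COc1ccc(CN(C(=O)CSc2nc3ccccc3s2)c2cc(OC)c(OC)c(OC)c2)cc1O`: 35 nM

Both values come from a functional assay on MGC-803 cells (Homo sapiens) for antiproliferative activity, read by MTT assay, with a stated time of 48 h; a lower number here means a stronger inhibitor, a higher number a weaker inhibitor. Compound 2 has the lower number of the pair, so it is the stronger inhibitor of the two. Compound 3 `COc1ccc(CN(C(=O)CSc2nc3ccccc3s2)c2cc(OC)c(OC)c(OC)c2)cc1[N+](=O)[O-]` keeps the shared core but has nitro in place of hydroxy on an aromatic carbon, ortho to a methoxy group: nitro in place of hydroxy on an aromatic carbon.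

Among the measured compounds shown here, one measured step bears on this change: a 180-fold lower number from compound 1 to compound 2 (2.26 log units; beyond the scatter), with hydroxy in place of methyl at that same place. Compound 3 also lacks the hydroxy, so much of that large drop may be lost. For the measured compounds named here, still, nitro is not methyl, and no measured compound carries it. A clear rise in this assay is therefore expected, probably smaller than that step. The expected change is a 43-fold higher number from compound 2 to compound 3 (1.63 log units; beyond the scatter). For compound 3 the estimated value is 1500 nM, with an expected range of 150 nM to 8000 nM.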

Compound 3, half-maximal inhibitory concentration: 682 nM
Estimate against measurement, compound 3: 2.2-fold (0.34 log units) above, and the stated range covers the measured number.
By their numbers in this assay, from the lowest: compound 2; then compound 3; then compound 1.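

In this assay, the group at this place does not act as a simple switch, since nitro loses much of the potency given by hydroxy (a 19-fold higher number from compound 2 to compound 3 (1.29 log units; beyond the scatter)) but still outperforms methyl (a 9.3-fold lower number from compound 1 to compound 3 (0.97 log units; beyond the scatter)). The three groups therefore form a graded series, with compound 2 lowest, compound 3 in the middle and compound 1 highest. Nitro brings no hydrogen-bond donor, so a donor at this place is not required for the gain over methyl, although the best of the three compounds does carry one. Nothing available here explains why these groups differ.

Going by these compounds, whether an amine or a carboxylic acid at this place would come closer to compound 2 remains open. So does whether a methoxy or a fluorine would fall above or below compound 3.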